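Shortening the alkoxy chain on a quinazolinone hydrazone

The compounds below may be only part of what the source reports. "The series", "measured", "known", "first", "only" and "open" are said of these compounds alone.

Measured compounds:
compound 1 `CCCOc1cccc(/C=N/n2c(-c3ccccc3)nc3ccccc3c2=O)c1` 30 mg/kg
compound 2 `O=c1c2ccccc2nc(-c2ccccc2)n1/N=C/c1cccc(OCc2ccccc2)c1` 300 mg/kg
compound 3 `C=CCCOc1cccc(/C=N/n2c(-c3ccccc3)nc3ccccc3c2=O)c1` 100 mg/kg

Of the compounds shown here, three have been tested in a functional assay on the whole organism (strain albino CF-1) with Mus musculus as the target, in the maximal electroshock model, with a stated time of 4 h; a lower number here means that less compound is needed, a higher number that more compound is needed for the effect. Compound 3 stands second highest of the three numbers: its nearest neighbour is compound 2, and the furthest is compound 1, as the steps of a 3.0-fold lower number from compound 2 to compound 3 (0.48 log units; beyond the scatter) and a 3.3-fold higher number from compound 1 to compound 3 (0.52 log units; beyond the scatter) show. The step of a 10-fold higher number from compound 1 to compound 2 (1.00 log units; beyond the scatter) is the largest seen.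

Compound 4 `CCOc1cccc(/C=N/n2c(-c3ccccc3)nc3ccccc3c2=O)c1` has not been measured. It differs from compound 3 as follows: hydrogen in place of vinyl on a saturated chain carbon, two bonds along the chain from an oxygen on an aromatic ring.

The step that bears most directly on this change is a 3.3-fold higher number from compound 1 to compound 3 (0.52 log units; beyond the scatter), where the chain was extended by the same vinyl group now removed. Across the three measured compounds, a smaller group on the chain carbon bound to the oxygen on the aromatic ring went with a lower number; no measured compound goes against this. Compound 4 is therefore expected to need a lower dose than compound 3, with an estimated step of a 3.3-fold lower number from compound 3 to compound 4 (0.52 log units; beyond the scatter). The estimate for compound 4 in this assay is 30 mg/kg, with a range from 10 mg/kg to 100 mg/kg.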

Compound 4, minimum effective dose: 100 mg/kg
Estimate against measurement, compound 4: 3.3-fold (0.52 log units) below; low and high end bracket the measured number.
By their numbers in this assay, from the lowest: compound 1; then compounds 3 and 4 (each within the scatter of the next); then compound 2.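

Removing the vinyl group gives no change at the digits printed from compound 3 to compound 4 (within the scatter) in this assay, so the step from the but-3-en-1-yl chain to the ethoxy chain leaves the required dose unresolved, and the shorter chain brings no gain at this position. Removing the methyl from the same chain carbon of compound 1 instead gives a 3.3-fold higher number from compound 1 to compound 4 (0.52 log units; beyond the scatter), and the ethoxy chain still compares favourably with the larger group of compound 2, with a 3.0-fold lower number from compound 2 to compound 4 (0.48 log units; beyond the scatter), so smaller is not simply better: compound 1 needs the lowest dose of the four, and compound 4 and compound 3 go against a steady trend with size. Nothing shown here accounts for this uneven response. From the compounds shown here alone, whether a methoxy group or a branched chain such as isopropoxy would match compound 1 remains open. So does the effect of an amine at the end of the chain.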